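Trifluoromethyl for Cyclobutylsulfanyl at the Carbonyl Carbon

A few compounds are considered here, and "the series" means these few. Any claim that something is new, unique, unknown or untested is made for them only; others in the source may bear on it.

In a functional assay on isolated protein for inhibition of Glucose-dependent insulinotropic receptor (Rattus norvegicus), read by HTRF and cAMP accumulation (a higher number here means a larger maximal response, a lower number a smaller maximal response), compound 1 `Cc1nc(S(C)(=O)=O)ccc1Oc1ncnc(OC2CCN(C(=O)OC(C)C)CC2)c1F` gives 77%, and compound 2 `Cc1nc(S(C)(=O)=O)ccc1Oc1ncnc(OC2CCN(C(=O)SC3CCC3)CC2)c1F` gives 81%. The step of a number 4 percentage points higher from compound 1 to compound 2 (within the scatter) is within the scatter, so compound 2 stands alongside compound 1 rather than apart from it. Compound 3 `Cc1nc(S(C)(=O)=O)ccc1Oc1ncnc(OC2CCN(C(=O)C(F)(F)F)CC2)c1F` differs from compound 2 by trifluoromethyl in place of cyclobutylsulfanyl on a carbonyl carbon. For the measured compounds named here, the only measured step at this carbonyl carbon, a number 4 percentage points higher from compound 1 to compound 2 (within the scatter), was small, so no step beyond the scatter in this assay is expected from this exchange either. For compound 3 in this assay a value of 78% is therefore expected, in a range from 65% to 90%. The expected step is a number 3 percentage points lower from compound 2 to compound 3 (within the scatter).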

Compound 3, largest response reached (reported as efficacy), in percent of the reference or control that the assay uses: 76%
The estimate for compound 3 lay 2 percentage points above the measured number; measured number inside the range.
By their numbers in this assay, from the lowest: compounds 3, 1 and 2 (each within the scatter of the next).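

In this assay the carbonyl carbon has now carried three different groups with no step beyond the scatter, as shown by a number 5 percentage points lower from compound 2 to compound 3 (within the scatter) and by a number 1 percentage points lower from compound 1 to compound 3 (within the scatter). Among these compounds, the maximal response therefore holds with trifluoromethyl, which has no ring and no hydrogen-bond acceptor, as it does with cyclobutylsulfanyl and isopropoxy. No measured evidence bears on why the response stays level. As far as these compounds go, whether an amine or a carboxylic acid on this carbonyl carbon would keep the response in the same range remains open. The same question stands for a longer chain.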